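The source may report more compounds than this note shows. Statements on the series, on what has been measured and on what is new or still open speak of the compounds shown alone.

Compound 1 `O=C(Nc1ccc(Cl)c(-c2nnc3c(Cl)cccn23)c1)c1ccccn1` and compound 2 `CS(=O)(=O)c1ccc(C(=O)Nc2ccc(Cl)c(-c3nnc4c(Cl)cccn34)c2)cc1` share the same core and differ only in the aromatic group attached to the amide carbonyl. In a functional assay on MCF7 cells (Homo sapiens) for antiproliferative activity, read by MTT assay, with a stated time of 72 h (a higher number here means a weaker inhibitor, a lower number a stronger inhibitor), compound 1 gives 96400 nM, and in this assay compound 2 gives 94200 nM; the step of a 1.0-fold lower number from compound 1 to compound 2 (0.01 log units; within the scatter) shows that exchanging one aromatic group for another at this position left the read-out essentially unchanged. Compound 2 therefore sits inside the usual scatter of compound 1, and neither can be called the stronger or weaker of the two. Compound 3 `O=C(Nc1ccc(Cl)c(-c2nnc3c(Cl)cccn23)c1)c1c(F)cccc1Cl` carries the next change at the same place: 2-chloro-6-fluorophenyl in place of 4-(methylsulfonyl)phenyl on a carbonyl carbon. Going by the values given here, the only comparable step is a 1.0-fold lower number from compound 1 to compound 2 (0.01 log units; within the scatter), which stayed within the scatter, so no step beyond the scatter is expected in this assay for compound 3, in either direction. The expected step is a 1.0-fold lower number from compound 2 to compound 3 (0.02 log units; within the scatter). Compound 3 is thus estimated at 90000 nM, with a range from 30000 nM to 250000 nM.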

Compound 3, half-maximal inhibitory concentration: > 100000 nM
Compound 3: no number, only a limit; the forecaster's own chance of this, stated with the estimate: 15%; middle value at least 1.1-fold (0.04 log units) away from the limit.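

For compound 3, this assay gives no number, only a limit of the assay: the limit of > 100000 nM in this assay, at which 1 of the 3 values shown sits.
From the compounds shown here alone, the comparison therefore yields only floors: an at least 1.0-fold higher number from compound 2 to compound 3 (0.02 log units; that floor lies within the scatter), and an at least 1.0-fold higher number from compound 1 to compound 3 (0.01 log units; that floor lies within the scatter), so the true size of each gap stays unknown. What this adds is that a third aromatic group, 2-chloro-6-fluorophenyl, which carries two halogens and has no hydrogen-bond acceptors, also gives no sign of a stronger inhibitor at this place on the carbonyl carbon.

All three groups shown here are six-membered aromatic rings, so it remains open how a non-aromatic group, such as an amine or a short alkyl chain, would read at this place. These three compounds also give no cause for the high numbers seen throughout.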